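This account rests on a few compounds, and the source may have more. Where it says the series, first, only, none or still open, it means among the compounds named here.

Measured in a functional assay on HeLa cells (Homo sapiens) for cytotoxicity, in the presence of a further agent that is not named here; on this read-out lower numbers stand for stronger inhibition and higher numbers for weaker inhibition:
- compound 1 `Cc1ccccc1-c1cc(-c2ccc(Cl)o2)cc(-c2ccsc2)n1`: 9770 nM
- compound 2 `Cc1ccc(-c2cc(-c3ccc(Cl)o3)cc(-c3ccsc3)n2)o1`: > 50000 nM (a limit of the assay, not a number)
- compound 3 `Clc1ccc(-c2cc(-c3ccco3)cc(-c3cccs3)n2)cc1`: 32700 nM

On these data alone, compound 2 stands at the limit of > 50000 nM in this assay, at which 1 of the 3 values shown sits, so its true position is unknown, and it can only be said to lie at the weak end of what this assay reports. The next compound, compound 4 `Clc1cccc(-c2cc(-c3ccc(Cl)o3)cc(-c3ccsc3)n2)c1`, changes one group of compound 2: 3-chlorophenyl in place of 5-methylfuran-2-yl on an aromatic carbon. In words, 3-chlorophenyl comes in place of 5-methylfuran-2-yl on an aromatic carbon, next to the ring nitrogen.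

Among the measured compounds shown here, one measured step bears on this change: an at least 5.1-fold higher number from compound 1 to compound 2 (0.70 log units; beyond the scatter). That step put 5-methylfuran-2-yl in place of 2-methylphenyl at the same carbon, and it lies beyond the scatter. For the measured compounds named here, compound 4 reverses that swap in kind, with a six-membered aromatic ring returning, although it carries a different group from the one in compound 1. Compound 4 is therefore expected to land in the neighbourhood of compound 1, at 9770 nM, perhaps somewhat weaker. Going by the values given here, compound 3, at 32700 nM, is joined to the others by no single-place step, so it supplies no step size.

The expected change is an at least 3.8-fold lower number from compound 2 to compound 4 (0.58 log units; beyond the scatter), towards a lower number and stronger inhibition. For compound 4 the estimate is 13000 nM, with an expected range of 4500 nM to 38000 nM.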

Compound 4, half-maximal inhibitory concentration: 8710 nM
For compound 4 the middle estimate is 1.5-fold (0.17 log units) above the measured one; low and high end bracket the measured number.
By their numbers in this assay, from the lowest: compounds 4 and 1 (each within the scatter of the next); then compound 3. At a limit, above all of these: compound 2.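

In this assay, putting a six-membered aromatic ring of carbon only back on the carbon next to the ring nitrogen gives an at least 5.7-fold lower number from compound 2 to compound 4 (0.75 log units; beyond the scatter), the opposite direction to the earlier at least 5.1-fold higher number from compound 1 to compound 2 (0.70 log units; beyond the scatter). The two compounds that carry such a ring then show a 1.1-fold lower number from compound 1 to compound 4 (0.05 log units; within the scatter), so 3-chlorophenyl and 2-methylphenyl cannot be told apart here, even though they differ in both the substituent and where it sits on the ring. On these data alone, the true size of the step to compound 4 stays unknown because compound 2 carries a limit of the assay rather than a number: the limit of > 50000 nM in this assay, at which 1 of the 4 values shown sits.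

As far as these compounds go, whether the weak result of compound 2 belongs to the furan ring itself or to its methyl group remains open, as does whether the chlorine of 3-chlorophenyl or the methyl of 2-methylphenyl matters at all compared with a plain phenyl. From the compounds shown here alone, how this carbon would respond to a phenyl ring bearing an amine or a carboxylic acid also remains open.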